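This account rests on a few compounds, and the source may have more. Where it says the series, first, only, none or still open, it means among the compounds named here.

Compound 1 `COc1cc2ncnc(Nc3ccc(Br)cc3Cl)c2c(OC)c1OC`: 49.7%
Compound 2 `COc1cc2ncnc(Nc3ccccc3[N+](=O)[O-])c2c(OC)c1OC`: 25.5%

Of the compounds shown here, two that share the same core have been measured so far. In a functional assay on PC-3 cells (Homo sapiens) for inhibition, read by MTT assay, with a stated time of 72 h, tested at 10 uM (on this read-out lower numbers stand for less inhibition of growth and higher numbers for more inhibition of growth at the one concentration tested), compound 1 gives 49.7%, whereas compound 2 gives 25.5%. Compound 2 thus stands at the lowest of the two numbers, and its nearest neighbour, compound 1, lies beyond the scatter above it.

The next compound, compound 3 `COc1cc2ncnc(Nc3ccccc3F)c2c(OC)c1OC`, differs from compound 2 in one place: fluoro in place of nitro on an aromatic carbon, in words a fluoro in place of a nitro on an aromatic carbon. Within the data shown here, no step between measured compounds tells what this exchange does, so the expectation rests on the two numbers alone. Compound 3 is expected to sit near compound 2, with a step from compound 2 to compound 3 of a number 4.5 percentage points higher from compound 2 to compound 3 (within the scatter) that is estimated to stay within the usual scatter. The estimate for compound 3 in this assay is 30%, in a range from 10% to 52%.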

Compound 3, percent growth inhibition at one concentration: 24%
Estimate against measurement, compound 3: 6 percentage points above; low and high end bracket the measured number.
By their numbers in this assay, from the lowest: compounds 3 and 2 (each within the scatter of the next); then compound 1.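

Exchanging the nitro for a fluoro on this aromatic carbon, ortho to a large group, gives in this assay a number 1.5 percentage points lower from compound 2 to compound 3 (within the scatter), so these two groups are not told apart here, though they differ in heavy atoms and hydrogen-bond acceptors. Exchanging the whole aromatic group on the nitrogen, with 2-fluorophenyl in place of 4-bromo-2-chlorophenyl, gives a number 25.7 percentage points lower from compound 1 to compound 3 (beyond the scatter), which shows that the number can move beyond the scatter with a change at that nitrogen, though this single step cannot assign the difference to any one atom. No independent measurement bears on why either step has the size it has.

From the compounds shown here alone, it remains open whether an amine, a hydroxyl or a methoxy at this position would leave the number equally unchanged. Also open, going by these compounds, is how much of the step from the 4-bromo-2-chlorophenyl group belongs to the bromo and how much to the chloro.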